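Meta-substituted benzyl pyrazoles: chloro for methyl

This account rests on a few compounds, and the source may have more. Where it says the series, first, only, none or still open, it means among the compounds named here.

Measured so far:
compound 1 `CCCn1c(=O)c2nc(-c3cnn(Cc4cccc(C)c4)c3)[nH]c2n(CCC)c1=O` — 48 nM
compound 2 `CCn1c(=O)c2nc(-c3cnn(Cc4ccccc4)c3)[nH]c2n(CC)c1=O` — 580 nM
compound 3 `Cn1c(=O)c2[nH]c(-c3cnn(Cc4cccc(F)c4)c3)nc2n(C)c1=O` — 460 nM

In an assay on CHO cells for displacement of a labelled ligand from adenosine receptor A1 (Homo sapiens) (a lower number here means a stronger inhibitor, a higher number a weaker inhibitor), compound 1 gives the lowest of the three numbers, 48 nM. Compound 3 comes nearest with 460 nM, and compound 2 stands furthest with 580 nM. Both gaps lie beyond the scatter, but compounds 2 and 3 each differ from compound 1 in more than one place, so no single change can be read out of them. Going by the values given here, no pair of measured compounds is separated by one change alone.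

Compound 4 `CCCn1c(=O)c2nc(-c3cnn(Cc4cccc(Cl)c4)c3)[nH]c2n(CCC)c1=O` is the next compound to be measured in this assay. Relative to compound 1 the change is chloro in place of methyl on an aromatic carbon. The benzyl group, its attachment to the pyrazole and the shared core are all kept, so the only question is how much a chloro in place of a methyl at the same meta position is worth.

There is no measured step of this kind in the series, and the one measured analogue that carries a halogen at that position, compound 3, also differs elsewhere. The step from compound 1 to compound 4 is therefore expected to be small, a 1.2-fold lower number from compound 1 to compound 4 (0.08 log units; within the scatter), and not beyond the scatter in either direction. For compound 4 the estimated value is 40 nM, with a range from 15 nM to 130 nM.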

Compound 4, inhibition constant: 31 nM
For compound 4 the middle estimate is 1.3-fold (0.11 log units) above the measured one; the measured number falls inside the stated range.
By their numbers in this assay, from the lowest: compounds 4 and 1 (each within the scatter of the next); then compounds 3 and 2 (each within the scatter of the next).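

Going by these compounds alone, the only step that changes one place, a 1.5-fold lower number from compound 1 to compound 4 (0.19 log units; within the scatter) in this assay, shows that 3-methylbenzyl and 3-chlorobenzyl cannot be told apart on the shared core of compound 1. At this position, meta to a large group on the six-membered aromatic ring, one heavy atom is exchanged for another, carbon for chlorine, with no hydrogen-bond donor or acceptor gained or lost, and the binding number stays within the usual scatter. No measurement beyond the binding numbers bears on this result.

Still open, from the compounds shown here alone, is how this position responds to groups of a different kind, such as an amine, a carboxylic acid or a longer chain, since methyl and chloro alone do not define its limits. Steps from compound 1 or compound 4 to compound 2 or compound 3 cannot be read, as each of these pairs differs in more than one place, so the separate contributions of the chains on the core and of a fluoro at this position remain unresolved.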